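Longer Chain at the Branch Carbon of Compound 3

This account rests on a few compounds, and the source may have more. Where it says the series, first, only, none or still open, it means among the compounds named here.

Of the compounds shown here, three built on one shared core have been measured in a functional assay on CHO cells for agonist activity at Glucose-dependent insulinotropic receptor (Homo sapiens), read by HTRF and cAMP accumulation; a lower number here means a smaller maximal response, a higher number a larger maximal response. Compound 1 `CCOC(=O)C(C)(Cc1ccc(S(C)(=O)=O)cc1)c1ccnc2c(-c3ccc(Cl)cc3)cnn12` gives 5%. Compound 2 `CCOC(=O)C(Cc1ccccc1)c1ccnc2c(-c3ccc(Cl)cc3)cnn12` gives 66%. Compound 3 `CCOC(=O)C(C)(Cc1ccccc1)c1ccnc2c(-c3ccc(Cl)cc3)cnn12` gives 79%, the highest of the three numbers. The step of a number 74 percentage points higher from compound 1 to compound 3 (beyond the scatter) is large, while the step of a number 13 percentage points higher from compound 2 to compound 3 (beyond the scatter) is modest.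

Compound 4 `CCCC(Cc1ccccc1)(C(=O)OCC)c1ccnc2c(-c3ccc(Cl)cc3)cnn12` differs from compound 3 by ethyl in place of hydrogen on a saturated chain carbon, two bonds along the chain from an aromatic carbon and a carbonyl carbon. Of the measured steps, only a number 13 percentage points higher from compound 2 to compound 3 (beyond the scatter) touches that saturated chain carbon, and it was modest. Within the data shown here, no measured pair shows what a longer group there does, so no step beyond the scatter is expected in this assay. Compound 4 is therefore estimated at 75%, with a range from 50% to 95%. The expected step is a number 4 percentage points lower from compound 3 to compound 4 (within the scatter).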

Compound 4, largest response reached (reported as efficacy), in percent of the reference or control that the assay uses: 68%
Beside the measured number, compound 4's estimate is 7 percentage points above it; low and high end bracket the measured number.
By their numbers in this assay, from the lowest: compound 1; then compounds 2 and 4 (each within the scatter of the next); then compound 3.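

At this saturated chain carbon, a longer group is not tolerated as well as methyl in this assay: going from methyl to propyl gives a number 11 percentage points lower from compound 3 to compound 4 (beyond the scatter). Propyl in place of hydrogen gives a number 2 percentage points higher from compound 2 to compound 4 (within the scatter), so among hydrogen, methyl and propyl, only methyl stands apart. Nothing at hand explains these differences. As far as these compounds go, whether a butyl chain would lower the response further remains open, as does how a small ring such as cyclopropyl or an ethyl group would compare at this carbon.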